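The source may report more compounds than this note shows. Statements on the series, on what has been measured and on what is new or still open speak of the compounds shown alone.

Working notes on the series. Within the data shown here, in an assay on lysate for inhibition of phosphatidylcholine:ceramide cholinephosphotransferase 2 (Homo sapiens), read by HPLC, with stated times of 30 min and 2 h (a lower number here means a stronger inhibitor, a higher number a weaker inhibitor), compound 3 `Cc1ccc(F)cc1COc1ccccc1C(=O)Nc1cccnc1` gives 740 nM, the lowest of the three numbers measured so far, though the gap to compound 2 `O=C(Nc1cccnc1)c1ccccc1OCc1cc(Cl)ccc1Cl`, which gives 990 nM, lies within the scatter. Compound 1 `N#Cc1cccc(COc2ccccc2C(=O)Nc2cccnc2)c1` gives 60700 nM and stands far apart from both. The two large movements in the set, a 61-fold lower number from compound 1 to compound 2 (1.79 log units; beyond the scatter) and an 82-fold lower number from compound 1 to compound 3 (1.91 log units; beyond the scatter), both follow the exchange of the 3-cyanophenyl for a halogen-bearing ring on the saturated chain carbon bound to the ring oxygen. The exchange between the two halogen-bearing rings, a 1.3-fold lower number from compound 2 to compound 3 (0.13 log units; within the scatter), stays within the scatter.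

Compound 4 `Cc1c(Cl)cccc1COc1ccccc1C(=O)Nc1cccnc1` carries the change (3-chloro-2-methylphenyl in place of 5-fluoro-2-methylphenyl on a saturated chain carbon bound to an oxygen on an aromatic ring). The 2-methyl is kept; fluorine leaves and chlorine enters at a different ring position. Among the measured compounds shown here, the only step that bears directly on such a halogen swap is a 1.3-fold lower number from compound 2 to compound 3 (0.13 log units; within the scatter), where a ring with two chlorines and a ring with fluorine and methyl gave numbers that cannot be told apart. For the measured compounds named here, no measured pair isolates the position of the halogen on its own. On this basis the expected step of a 1.1-fold higher number from compound 3 to compound 4 (0.06 log units; within the scatter) is small and within the scatter, in no firm direction. Compound 4 is estimated at 850 nM, with a range from 300 nM to 2500 nM.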

Compound 4, half-maximal inhibitory concentration: 3800 nM
For compound 4 the middle estimate is 4.5-fold (0.65 log units) below the measured one; measured number outside the range, above it.
By their numbers in this assay, from the lowest: compounds 3 and 2 (each within the scatter of the next); then compound 4; then compound 1.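

In this assay, among these compounds, the place on a saturated chain carbon bound to an oxygen on an aromatic ring proves more sensitive among halogen-bearing rings than the earlier compounds suggested: with the methyl kept, 3-chloro-2-methylphenyl in place of 5-fluoro-2-methylphenyl gives a 5.1-fold higher number from compound 3 to compound 4 (0.71 log units; beyond the scatter) and is beyond the scatter. The same ring in place of 2,5-dichlorophenyl gives a 3.8-fold higher number from compound 2 to compound 4 (0.58 log units; beyond the scatter) and is also beyond the scatter, so the near equality of compound 2 and compound 3 does not extend to every ring bearing a halogen, while 3-chloro-2-methylphenyl in place of 3-cyanophenyl still gives a 16-fold lower number from compound 1 to compound 4 (1.20 log units; beyond the scatter) and leaves compound 4 in the middle of the set. No measurement at hand accounts for this difference between the rings.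

The compounds shown do not separate the identity of the halogen from where it sits, since fluorine in compound 3 and chlorine in compound 4 differ in both respects. Also open, going by these compounds, is how this place would respond to a ring carrying a methoxy group or an amine, or to a 5-chloro-2-methylphenyl ring.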